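Pyrimidin-2-yl Replaces 3-Chlorophenyl on the Ring Amine

This account rests on a few compounds, and the source may have more. Where it says the series, first, only, none or still open, it means among the compounds named here.

Compound 3 `O=C1CC(c2ccccc2Br)C(=O)N1CN1CCN(c2cccc(Cl)c2)CC1` was tested in a functional assay on the whole organism (strain CF-1 albino) with Mus musculus as the target, with a stated time of 4 h (a lower number here means that less compound is needed, a higher number that more compound is needed for the effect), where compound 3 gives 100 mg/kg. Compound 2 `O=C1CC(c2ccccc2F)C(=O)N1CN1CCN(c2cccc(C(F)(F)F)c2)CC1` gives 100 mg/kg there, and compound 1 `O=C1CC(c2ccccc2F)C(=O)N1CN1CCN(c2ccc(F)cc2)CC1` gives 30 mg/kg. Compound 3 thus stands level with compound 2, the two together the highest numbers of the three, and beyond the scatter from compound 1. Going by the values given here, the one measured single-point step, a 3.3-fold higher number from compound 1 to compound 2 (0.52 log units; beyond the scatter), exchanges one aryl group for another on the same ring nitrogen.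

Compound 4 `O=C1CC(c2ccccc2Br)C(=O)N1CN1CCN(c2ncccn2)CC1` differs from compound 3 in one place: pyrimidin-2-yl in place of 3-chlorophenyl on an amine nitrogen in a ring. Among the compounds with values here, no measured step exchanges an aromatic ring of carbon only for one with hetero atoms, so the earlier step bears only loosely on this change. Compound 4 is therefore expected to show a 1.7-fold lower number from compound 3 to compound 4 (0.22 log units; within the scatter), an estimate of 60 mg/kg with a range from 20 mg/kg to 200 mg/kg.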

Compound 4, minimum effective dose: 100 mg/kg
Estimate against measurement, compound 4: 1.7-fold (0.22 log units) below, within the range that was stated.
By their numbers in this assay, from the lowest: compound 1; then compounds 2, 3 and 4 (each within the scatter of the next).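

In this assay, going by these compounds alone, pyrimidin-2-yl in place of 3-chlorophenyl on an amine nitrogen in a ring gives no change at the digits printed from compound 3 to compound 4 (within the scatter), the first measured exchange here of an aromatic ring of carbon only for one with hetero atoms. At this position, with the shared core held, the entry of 2 hydrogen-bond acceptors and the loss of chlorine leave the dose reading unmoved. Nothing measured here accounts for this result. On these data alone, whether pyridin-2-yl or unsubstituted phenyl on the same nitrogen would read alike remains open.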